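A few compounds are considered here, and "the series" means these few. Any claim that something is new, unique, unknown or untested is made for them only; others in the source may bear on it.

Measured in an ADME assay on HCT-116 cells (Homo sapiens) for cytotoxicity, read by CellTiter-Glo, with a stated time of 72 h; a lower number here means a stronger inhibitor, a higher number a weaker inhibitor:

Compound 1 `CC1CCN(C2CCN(S(=O)(=O)c3cccnc3Cl)CC2)CC1`: > 10000 nM
Compound 2 `COc1ccc(-c2cccc(S(=O)(=O)N3CCC(N4CCC(C)CC4)CC3)c2)cc1`: > 5000 nM

Neither compound has yet given a number in this assay. For compound 2, the reading of > 5000 nM is a limit of the assay and not a number. For compound 1, the reading of > 10000 nM is likewise a limit. Within the data shown here, these two readings set no order between the compounds, and no measured step between compounds that differ in one place is available to size a change.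

The next compound, compound 3 `Cc1cccc(S(=O)(=O)N2CCC(N3CCC(C)CC3)CC2)c1`, has methyl in place of 4-methoxyphenyl on an aromatic carbon of a six-membered aromatic ring of carbon only, meta to a large group: methyl in place of 4-methoxyphenyl on an aromatic carbon. The expectation therefore rests only on the two limits, and a further limit is expected to be the likeliest report. The expected step, a step that the limit leaves unreadable from compound 2 to compound 3, is small and is not expected to go beyond the scatter. Compound 3 is estimated at 8000 nM, with an expected range from 3000 nM to 20000 nM.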

Compound 3, half-maximal inhibitory concentration: > 5000 nM
Compound 3 gave a limit, no number; the forecaster's own chance of this, stated with the estimate: 75%; the middle value does not contradict the limit.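

No step can be read from compound 3 to compound 1 or to compound 2: in this assay all three readings are limits of the assay, not numbers. The compounds shown leave open where the actual values lie, and whether methyl in place of 4-methoxyphenyl on an aromatic carbon changes the reading at all.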